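The compounds below may be only part of what the source reports. "The series", "measured", "known", "first", "only" and "open" are said of these compounds alone.

Compound 1, `CCCc1ccc(N2C(=O)NC3(CSC4=C3C(=O)c3ncccc3C4=O)C2=O)cc1`, is the starting point. For the measured compounds named here, in a functional assay on XF498 cells (Homo sapiens) for antiproliferative activity, read by MTT assay, with a stated time of 96 h (a higher number here means a weaker inhibitor, a lower number a stronger inhibitor), compound 1 gives 450 nM, the lowest of the three numbers measured so far, although the other two lie within the usual scatter of it. Compound 2, `COc1ccc(N2C(=O)NC3(CSC4=C3C(=O)c3ncccc3C4=O)C2=O)cc1`, gives 650 nM in this assay, and compound 3, `CCCCCc1ccc(N2C(=O)NC3(CSC4=C3C(=O)c3ncccc3C4=O)C2=O)cc1`, gives 830 nM. The three steps among them are all small: a 1.4-fold higher number from compound 1 to compound 2 (0.16 log units; within the scatter), a 1.8-fold higher number from compound 1 to compound 3 (0.27 log units; within the scatter) and a 1.3-fold higher number from compound 2 to compound 3 (0.11 log units; within the scatter). Compound 4, `CC(C)(C)c1ccc(N2C(=O)NC3(CSC4=C3C(=O)c3ncccc3C4=O)C2=O)cc1`, differs from compound 1 in one place: tert-butyl in place of propyl on an aromatic carbon. The step most like this one is the one in which ethyl replaced hydrogen on the chain, a 1.8-fold higher number from compound 1 to compound 3 (0.27 log units; within the scatter), and the step with methoxy in place of propyl, a 1.4-fold higher number from compound 1 to compound 2 (0.16 log units; within the scatter), also stayed within the scatter. So in this assay a change of this kind is expected to move the number little, if at all, and the estimated step is a 1.3-fold higher number from compound 1 to compound 4 (0.12 log units; within the scatter). Compound 4 is therefore estimated at 600 nM in this assay, with a likely range from 250 nM to 1500 nM.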

Compound 4, half-maximal inhibitory concentration: 850 nM
For compound 4 the middle estimate is 1.4-fold (0.15 log units) below the measured one; measured number inside the range.
By their numbers in this assay, from the lowest: compounds 1, 2, 3 and 4 (each within the scatter of the next).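

At this aromatic carbon, the swap from a straight propyl to a branched tert-butyl gives a 1.9-fold higher number from compound 1 to compound 4 (0.28 log units; within the scatter) in this assay, so branching of this size does not separate the two compounds. The exchanges with the other groups read the same way, with a 1.0-fold higher number from compound 3 to compound 4 (0.01 log units; within the scatter) for tert-butyl against pentyl and a 1.3-fold higher number from compound 2 to compound 4 (0.12 log units; within the scatter) for tert-butyl against methoxy. All four groups at this place therefore give numbers within the scatter of one another, and nothing available explains why the assay hardly distinguishes them.

Still open, going by these compounds, is whether any group here can move the number beyond the scatter, for instance an amine or a carboxylic acid. A plain hydrogen at this carbon would show whether these groups matter at all.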